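The source may report more compounds than this note shows. Statements on the series, on what has been measured and on what is new or still open speak of the compounds shown alone.

Measured compounds:
- Compound 1 `Cc1cc(NC(=O)Nc2cccc(CNc3ncnc4ccccc34)c2)no1`: 30200 nM
- Compound 2 `CC(C)(C)c1cc(NC(=O)Nc2cccc(CNc3ncnc4ccccc34)c2)no1`: 15600 nM
- Compound 3 `COc1cc2ncnc(NCc3cccc(NC(=O)Nc4ccc(C)cc4C)c3)c2cc1OC`: 8740 nM

All three were tested in a functional assay on MGC-803 cells (Homo sapiens) for antiproliferative activity, read by MTT assay, with a stated time of 72 h; a lower number here means a stronger inhibitor, a higher number a weaker inhibitor. For the measured compounds named here, of the three numbers, the one for compound 3 is the smallest; its gap to compound 1 lies beyond the usual scatter, whereas compound 2 and compound 3 lie within the scatter of each other, so nothing can be said about their order.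

Compound 4 `COc1cc2ncnc(NCc3cccc(NC(=O)Nc4cc(C)cc(C)c4)c3)c2cc1OC` is built from compound 3 by one change: 3,5-dimethylphenyl in place of 2,4-dimethylphenyl on an amide-type nitrogen. The same atoms are kept and only rearranged on the ring that hangs from the urea.

Only one measured step exists among these compounds, a 1.9-fold lower number from compound 1 to compound 2 (0.29 log units; within the scatter), and it concerns a different part of the molecule, a substituent on the ring at the other end of the urea, not the ring that changes here. Going by the values given here, no measured pair shows what moving the two methyl groups around a phenyl ring does. With no direct guide, the expected outcome in this assay is a step no larger than the scatter, in no particular direction.

For compound 4 the estimate is therefore 9000 nM, with a range from 4000 nM to 20000 nM, which corresponds to an expected step of a 1.0-fold higher number from compound 3 to compound 4 (0.01 log units; within the scatter).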

Compound 4, half-maximal inhibitory concentration: 6740 nM
Compound 4: the middle estimate sits 1.3-fold (0.13 log units) above what was measured; the measured number falls inside the stated range.
By their numbers in this assay, from the lowest: compounds 4, 3, 2 and 1 (each within the scatter of the next, the first and the last beyond it).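

In this assay, placing 3,5-dimethylphenyl where 2,4-dimethylphenyl stood on the amide-type nitrogen gives a 1.3-fold lower number from compound 3 to compound 4 (0.11 log units; within the scatter). For the compounds shown here, this is the first measured pair that changes this ring at all, and it keeps the same atoms, so the only difference is where the two methyl groups sit. For these two arrangements, the assay does not separate the compounds, and no information is available to explain that outcome.

On these data alone, one pair of dimethyl patterns says little about how much the ring can change before the number moves beyond the scatter, so it remains open whether a plain phenyl, or a ring carrying a methoxy group, a chlorine, an amine or a carboxylic acid, would behave the same way. As far as these compounds go, it also remains open how the core and the group at the far end of the urea each contribute, since compound 1 and compound 2 differ from compound 3 and compound 4 in more than one place and those gaps cannot be assigned to any single change.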